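The compounds below may be only part of what the source reports. "The series", "measured", "known", "first", "only" and "open" are said of these compounds alone.

Compound 1 `CN(C(=O)c1cc(F)ccc1O)c1ccc(C#N)cc1`: in a functional assay on KG-1 cells (Homo sapiens) for cytotoxicity, read by luminescence and CellTiter-Glo, with a stated time of 3 days (on this read-out lower numbers stand for stronger inhibition and higher numbers for weaker inhibition), compound 1 reaches only a limit of the assay, > 10000 nM.
Compound 2 `N#Cc1ccc(NC(=O)c2cc(Cc3ccccc3)ccc2O)cc1`: in this assay compound 2 gives 1930 nM.
Compound 3 `N#Cc1ccc(NC(=O)c2cc(F)ccc2O)cc1`: in this assay compound 3 gives 2670 nM.

Among the values reported as numbers, compound 3 sits within the scatter of compound 2, its nearest neighbour, as the step of a 1.4-fold higher number from compound 2 to compound 3 (0.14 log units; within the scatter) shows. The other measured step, an at least 3.7-fold lower number from compound 1 to compound 3 (0.57 log units; beyond the scatter), is at least modest. Compound 4 `O=C(Nc1ccc([N+](=O)[O-])cc1)c1cc(F)ccc1O` differs from compound 3 in one place: nitro in place of cyano on an aromatic carbon. Within the data shown here, neither measured step concerns this position or either of these groups, so no measured step bears on the change. For that reason a step no larger than the scatter is expected, a 1.0-fold higher number from compound 3 to compound 4 (0.00 log units; within the scatter). Compound 4 is estimated at 2700 nM, with a range from 1000 nM to 7500 nM.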

Compound 4, half-maximal inhibitory concentration: 1100 nM
Compound 4: the middle estimate sits 2.5-fold (0.39 log units) above what was measured, and the stated range covers the measured number.
By their numbers in this assay, from the lowest: compounds 4, 2 and 3 (each within the scatter of the next, the first and the last beyond it). At a limit, above all of these: compound 1.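

In this assay swapping the nitrile for nitro gives a 2.4-fold lower number from compound 3 to compound 4 (0.39 log units; beyond the scatter) and so a step beyond the scatter. Among these compounds, the earlier steps changed only the amide nitrogen and the fluoro carbon, so this is the first sign that the group on this carbon, para to a large group, affects the number. Nothing among the data shown explains why the number moves.

From the compounds shown here alone, whether an amine or a carboxylic acid on this carbon would lower the number further remains open. So does whether nitro has the same effect with benzyl in place of fluoro.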